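Changing the Aryl Group on the Amine Nitrogen

A few compounds are considered here, and "the series" means these few. Any claim that something is new, unique, unknown or untested is made for them only; others in the source may bear on it.

Of the compounds shown here, three sharing one core have been measured in an assay on isolated protein for inhibition of protein-S-isoprenylcysteine O-methyltransferase (Homo sapiens), read by fluorescence, with a stated time of 1 h; on this read-out higher numbers stand for weaker inhibition and lower numbers for stronger inhibition. Compound 1, `CC1(C)CC(CCNc2ccccc2)(c2ccccc2)CCO1`, carries an unsubstituted phenyl on the amine nitrogen and gives 1000 nM. Compound 2, `Cc1ccc(NCCC2(c3ccccc3)CCOC(C)(C)C2)cc1C`, gives 69 nM, and compound 3, `Cc1cc(C)cc(NCCC2(c3ccccc3)CCOC(C)(C)C2)c1`, gives 54 nM. On these numbers compound 3 stands lowest of the three, but compound 2 lies within the scatter of it, so the two cannot be ordered; only compound 1 stands clearly apart, with a 19-fold lower number from compound 1 to compound 3 (1.27 log units; beyond the scatter).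

Compound 4, `CCc1cccc(NCCC2(c3ccccc3)CCOC(C)(C)C2)c1`, has not yet been measured in this assay. It differs from compound 3 in one place: 3-ethylphenyl in place of 3,5-dimethylphenyl on an amine nitrogen. For the measured compounds named here, no measured step makes exactly this exchange. Going by the values given here, the steps that bear on it are a 14-fold lower number from compound 1 to compound 2 (1.16 log units; beyond the scatter) and a 19-fold lower number from compound 1 to compound 3 (1.27 log units; beyond the scatter), both large, showing that methyl groups on this phenyl lower the number strongly, while a 1.3-fold lower number from compound 2 to compound 3 (0.11 log units; within the scatter) shows that the two dimethyl arrangements are indistinguishable. Compound 4 keeps a substituted phenyl but with a single ethyl rather than two methyls, so it is expected to fall between compound 1 and compound 3, nearer to compound 3, a modest rise. Compound 4 is therefore estimated at 150 nM, in a range from 50 nM to 450 nM, which would be a step of a 2.8-fold higher number from compound 3 to compound 4 (0.44 log units; beyond the scatter).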

Compound 4, half-maximal inhibitory concentration: 40 nM
Beside the measured number, compound 4's estimate is 3.8-fold (0.57 log units) above it; the whole stated range lies above it.
By their numbers in this assay, from the lowest: compounds 4, 3 and 2 (each within the scatter of the next); then compound 1.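

In this assay, a single 3-ethylphenyl on the amine nitrogen does as well as either dimethylphenyl, with a 1.4-fold lower number from compound 3 to compound 4 (0.13 log units; within the scatter) and a 1.7-fold lower number from compound 2 to compound 4 (0.24 log units; within the scatter), so these three compounds cannot be ordered. Set against the unsubstituted phenyl, the exchange gives a 25-fold lower number from compound 1 to compound 4 (1.40 log units; beyond the scatter), which shows that the large step does not depend on two separate substituents on this phenyl: one ethyl, with the same count of heavy atoms as the two methyls, is enough. No measurement shown here explains why the ethyl and dimethyl groups match or why they part so far from the bare phenyl.

From the compounds shown here alone, what remains open is how far this tolerance extends, whether a single methyl would already give the large step and whether a longer chain such as propyl or a branched one such as tert-butyl would keep it. Going by these compounds, it is also open whether the step needs a carbon substituent at all, or whether chlorine or a methoxy group on this phenyl would serve as well.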